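Imidazole substituent swap: branched alkyl for 2-cyanophenyl

The compounds below may be only part of what the source reports. "The series", "measured", "known", "first", "only" and "open" are said of these compounds alone.

Compound 3 `N#Cc1ccccc1Cc1cnc(CCc2ccc(-c3ccccc3C(=O)O)cc2)[nH]1` gives 642 nM in an in vitro functional assay on cells for agonist activity at Bombesin receptor subtype-3 (Mus musculus), read by luminescence and calcium flux (a higher number here means that more compound is needed for the effect, a lower number that less compound is needed), the highest of the three numbers; compound 2 `CCCCc1cnc(C(CC)Cc2ccc(-c3ccccc3C(=O)O)cc2)[nH]1` gives 340 nM, within the scatter of it, while compound 1 `CCCCc1cnc(C(CCCO)Cc2ccc(-c3ccccc3C(=O)O)cc2)[nH]1` gives 238 nM, beyond the scatter. Among the measured compounds shown here, the only measured step, a 1.4-fold higher number from compound 1 to compound 2 (0.15 log units; within the scatter), alters a remote chain and says nothing about the imidazole substituent. Compound 4 `CCC(C)(CC)Cc1cnc(CCc2ccc(-c3ccccc3C(=O)O)cc2)[nH]1` differs from compound 3 by 1-ethyl-1-methylpropyl in place of 2-cyanophenyl on a saturated chain carbon bound to an aromatic carbon. For the measured compounds named here, no measured pair bears directly on this change, so the expectation rests on the shared core alone and is wide. For compound 4 the estimate is 450 nM, between 120 nM and 1600 nM, a step of a 1.4-fold lower number from compound 3 to compound 4 (0.15 log units; within the scatter) that is expected to sit within the scatter.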

Compound 4, half-maximal effective concentration: 30 nM
Compound 4: the middle estimate sits 15-fold (1.18 log units) above what was measured; the measured number lies below the stated range.
By their numbers in this assay, from the lowest: compound 4; then compounds 1, 2 and 3 (each within the scatter of the next, the first and the last beyond it).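

In this assay, among the compounds shown here, the group on a saturated chain carbon bound to an aromatic carbon proves decisive: 1-ethyl-1-methylpropyl in place of 2-cyanophenyl gives a 21-fold lower number from compound 3 to compound 4 (1.33 log units; beyond the scatter) and is the only step beyond the scatter. The 2-cyanophenyl ring and its nitrile are therefore not required for agonist activity. No evidence explains the size of this change.

A plain phenyl or a straight pentyl chain at this place would show whether the branching or the loss of the nitrile matters. Going by these compounds, whether 1-ethyl-1-methylpropyl also carries over to the cores of compound 1 and compound 2 remains open.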